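Halogen swap on the aryl ring and tolerated concentration

The source may report more compounds than this note shows. Statements on the series, on what has been measured and on what is new or still open speak of the compounds shown alone.

Four compounds sharing one core are compared in an ADME assay on MT4 cells (Homo sapiens) for cytotoxicity; a higher number here means that more compound is tolerated, a lower number that less compound is tolerated. Compound 1 `O=C(CSc1snnc1-c1ccc(Cl)cc1Cl)Nc1ccccc1F` gives 19500 nM. Compound 2 `O=C(CSc1snnc1-c1ccc(F)cc1F)Nc1ccccc1F` gives 148000 nM, and compound 3 `O=C(CSc1snnc1-c1ccc(F)cc1F)Nc1ccccc1Br` gives 144000 nM. Compound 2 and compound 3 differ in the core as counted here: bromo in place of fluoro on an aromatic carbon; that change gives a 1.0-fold lower number from compound 2 to compound 3 (0.01 log units; within the scatter). The change from compound 2 to compound 1 is 2,4-dichlorophenyl in place of 2,4-difluorophenyl on an aromatic carbon and gives a 7.6-fold lower number from compound 2 to compound 1 (0.88 log units; beyond the scatter). For the measured compounds named here, compound 4 `O=C(CSc1snnc1-c1ccc(Cl)cc1Cl)Nc1ccccc1Br` has not been measured; it differs from compound 3 by 2,4-dichlorophenyl in place of 2,4-difluorophenyl on an aromatic carbon, the same change as the one from compound 2 to compound 1, at the same place. Going by the values given here, the expectation for compound 4 rests on that earlier step, the one from compound 2 to compound 1 a 7.6-fold lower number from compound 2 to compound 1 (0.88 log units; beyond the scatter), applied to compound 3 and its value 144000 nM. The step from compound 3 to compound 4 is therefore expected to be a 7.6-fold lower number from compound 3 to compound 4 (0.88 log units; beyond the scatter). Compound 4 is estimated to give 19000 nM, with a likely range from 8000 nM to 45000 nM.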

Compound 4, half-maximal cytotoxic concentration: >= 146000 nM
Compound 4 ended at the assay's limit (the forecaster's own chance of this, stated with the estimate: 5%); middle value at least 7.6-fold (0.88 log units) away from the limit.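

In this assay compound 4 gives >= 146000 nM, which is a limit of the assay and not a number.

Even so, 2,4-dichlorophenyl in place of 2,4-difluorophenyl does not carry from one core to the other in this series, giving an at least 1.0-fold higher number from compound 3 to compound 4 (0.00 log units; that floor lies within the scatter), and this stands apart from the earlier step: the same change on two cores in this assay, a 7.6-fold lower number (0.88 log units; beyond the scatter) from compound 2 to compound 1 and an at least 1.0-fold higher number (0.00 log units; that floor lies within the scatter) from compound 3 to compound 4, at least 7.6-fold (0.88 log units) apart, beyond the scatter of two such steps

The bromo in place of fluoro change does not carry either, giving an at least 7.4-fold higher number from compound 1 to compound 4 (0.87 log units; beyond the scatter), but these pairs do not show the full size of either step onto compound 4, nor do they show any cause for the difference: the same change on two cores in this assay, a 1.0-fold lower number (0.01 log units; within the scatter) from compound 2 to compound 3 and an at least 7.4-fold higher number (0.87 log units; beyond the scatter) from compound 1 to compound 4, at least 7.6-fold (0.88 log units) apart, beyond the scatter of two such steps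

The compounds shown leave open whether the 2,4-dichlorophenyl change would again differ between cores with a methoxy group or an amine in place of the bromo or fluoro. They also leave open how a carboxylic acid at that place would alter the number in this assay, whichever of the two halogenated phenyl groups the core carries.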